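The compounds below may be only part of what the source reports. "The series", "measured", "known", "first", "only" and "open" are said of these compounds alone.

Measured so far: compound 1 `CCCCCCSC[C@H]1C2CC[C@@H](O2)[C@H]1C/C=C\CCCC(=O)O` and compound 2 `CSCSCC1C2CCC(O2)C1C/C=C\CCCC(=O)O`.

In a functional assay on a cell-free system (plasma) for inhibition of thromboxane A2 receptor (Homo sapiens) (on this read-out higher numbers stand for weaker inhibition and lower numbers for stronger inhibition), compound 1 gives 115000 nM; > 1000000 nM; > 1000000 nM (3 entries). In this assay, among the measured compounds shown here, compound 2 gives 700 nM, the only single number it has here, with one further entry that returned no number. Compound 3 `O=C(O)CCC/C=C\CC1C2CCC(O2)C1CSCCCc1ccccc1` has not been measured in this assay. Its difference from compound 2 is phenethyl in place of methylsulfanyl on a saturated chain carbon bound to a sulfur. For the measured compounds named here, no step between measured compounds is available to calibrate this change, so the expectation rests on what compounds 1 and 2 show: the longer sulfur-bound chain of compound 1 sits far weaker than compound 2. The step of a 4.3-fold higher number from compound 2 to compound 3 (0.63 log units; beyond the scatter) is therefore expected to run toward weaker inhibition, beyond the scatter. Compound 3 is estimated at 3000 nM, within a range from 400 nM to 40000 nM.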

Compound 3, half-maximal inhibitory concentration: 5000 nM
For compound 3 the middle estimate is 1.7-fold (0.22 log units) below the measured one; the measured number falls inside the stated range.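

In this assay the change reads as a 7.1-fold higher number from compound 2 to compound 3 (0.85 log units; beyond the scatter), so phenethyl in place of methylsulfanyl on a saturated chain carbon bound to a sulfur weakens inhibition, yet compound 3 still returns a single number, 5000 nM. This is the only step shown at this place, and it indicates that the place accepts a group with a six-membered aromatic ring at a modest cost. Compound 1 offers no single number for comparison, since its entries include limits of the assay: the several entries of compound 1 in this assay, 115000 nM; > 1000000 nM; > 1000000 nM (3 entries)

The compounds shown do not separate the effect of the added chain length, the aromatic ring and the departing sulfur, as this one change alters all three at once. Going by these compounds, how an amine or a hydroxyl group at the end of this chain would read also remains open.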